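Isopentyl in Place of 4-Fluorophenyl

This account rests on a few compounds, and the source may have more. Where it says the series, first, only, none or still open, it means among the compounds named here.

In an ADME assay for permeability, using PAMPA, with a stated time of 30 min, at pH 7.4 (a higher number here means that the compound crosses the layer faster, a lower number that the compound crosses the layer more slowly), compound 1 (`CC(C)(C)c1ccc(Oc2ccc3c(NCCCNCc4ccco4)ccnc3c2)cc1`) gives 317 10^-6 cm/s and compound 2 (`Fc1ccc(-c2ccc3c(NCCCNCc4ccco4)ccnc3c2)cc1`) gives 237 10^-6 cm/s, two values within the scatter of each other. Compound 3 (`CC(C)CCc1ccc2c(NCCCNCc3ccco3)ccnc2c1`) differs from compound 2 by carrying isopentyl in place of 4-fluorophenyl on an aromatic carbon of the shared core (isopentyl in place of 4-fluorophenyl on an aromatic carbon). For the measured compounds named here, no measured pair of compounds shows a change of this kind. The estimated step of a 1.1-fold lower number from compound 2 to compound 3 (0.03 log units; within the scatter) is expected to stay within the scatter, with no firm direction. For compound 3 the expected value is 220 10^-6 cm/s, with a range of 100 10^-6 cm/s to 450 10^-6 cm/s.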

Compound 3, apparent permeability: 23 10^-6 cm/s
Compound 3: middle estimate off by 9.6-fold (0.98 log units), on the high side, outside the stated range (below it).
By their numbers in this assay, from the lowest: compound 3; then compounds 2 and 1 (each within the scatter of the next).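

The two earlier compounds stood within the scatter of each other, and so gave no sign that this aromatic carbon matters in this assay. Isopentyl in place of 4-fluorophenyl now brings a 10-fold lower number from compound 2 to compound 3 (1.01 log units; beyond the scatter), so the read-out does depend on the group held at this position. Nothing shown accounts for this drop.

On these data alone, whether the ring that leaves or the chain that enters decides the outcome remains open. A cyclohexyl group or a shorter chain such as ethyl on this carbon would bear on that question.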